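The source may report more compounds than this note shows. Statements on the series, on what has been measured and on what is new or still open speak of the compounds shown alone.

Measured so far in a functional assay on HeLa cells (Homo sapiens) for antiproliferative activity, read by MTT assay, with a stated time of 72 h; on this read-out lower numbers stand for stronger inhibition and higher numbers for weaker inhibition:
- compound 1 `Nc1nc(N)c2cc(CSC(=S)N3CCN(c4ccc([N+](=O)[O-])cc4)CC3)ccc2n1`: 1660 nM
- compound 2 `Nc1nc(N)c2cc(CSC(=S)N3CCN(c4ccccn4)CC3)ccc2n1`: 5090 nM

Within the data shown here, of these two, compound 2 has the higher number at 5090 nM and is therefore the weaker, with compound 1 as its only neighbour at 1660 nM. The next analogue, compound 3 `Nc1nc(N)c2cc(CSC(=S)N3CCN(c4ncccn4)CC3)ccc2n1`, differs from compound 2 in a single place: pyrimidin-2-yl in place of pyridin-2-yl on an amine nitrogen in a ring. In words, pyrimidin-2-yl stands in place of pyridin-2-yl on an amine nitrogen in a ring.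

Among the measured compounds shown here, only one measured step bears on this position, a modest one: a 3.1-fold higher number from compound 1 to compound 2 (0.49 log units; beyond the scatter), with pyridin-2-yl in place of 4-nitrophenyl. For the measured compounds named here, that step exchanged a different pair of groups, and no measured compound carries pyrimidin-2-yl, so the data give no firm direction. With two closely matched rings, a smaller step than that one is expected in this assay, most likely within the scatter. The estimated step is a 1.1-fold lower number from compound 2 to compound 3 (0.05 log units; within the scatter). For compound 3 the estimated value is 4500 nM, with an expected range of 1800 nM to 11000 nM.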

Compound 3, half-maximal inhibitory concentration: 4360 nM
Compound 3: the middle estimate sits 1.0-fold (0.01 log units) above what was measured, within the range that was stated.
By their numbers in this assay, from the lowest: compound 1; then compounds 3 and 2 (each within the scatter of the next).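

In this assay, pyrimidin-2-yl in place of pyridin-2-yl on the amine nitrogen of the ring gives a change that stays inside the scatter (a 1.2-fold lower number from compound 2 to compound 3 (0.07 log units; within the scatter)), so 2 hetero atoms instead of 1, and 2 hydrogen-bond acceptors instead of 1, do not separate these two compounds at this position. The step from the 4-nitrophenyl compound to the pyrimidin-2-yl compound (a 2.6-fold higher number from compound 1 to compound 3 (0.42 log units; beyond the scatter)) lies beyond the scatter and is modest, like the earlier step to pyridin-2-yl, which places compounds 2 and 3 together on the weaker side of compound 1. No measured evidence accounts for this pattern.

In the steps from compound 1, the nitro group and the benzene ring are replaced together, so the compounds shown cannot tell which of the two matters; an unsubstituted phenyl or a 4-methoxyphenyl at this place would bear on that question. Also open, as far as these compounds go, is how a non-aromatic group on the same nitrogen, such as a cyclohexyl or an acetyl, would compare with these aromatic rings.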